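Swapping chloro for trifluoromethyl on a benzyl ether

The source may report more compounds than this note shows. Statements on the series, on what has been measured and on what is new or still open speak of the compounds shown alone.

Measured compounds:
compound 1, `O=C(NC(=S)Nc1ccc(Cl)c(-c2nc3ccccc3[nH]2)c1)c1ccc(OCc2ccc(Cl)c(Cl)c2)cc1`, giving 24900 nM in a functional assay on SW-620 cells (Homo sapiens) for inhibition, read by MTT assay, with a stated time of 48 h; on this read-out lower numbers stand for stronger inhibition and higher numbers for weaker inhibition
compound 2, `Cc1ccc(NC(=O)NC(=O)c2ccc(OCc3cccc(Cl)c3)cc2)cc1-c1nc2ccccc2[nH]1`, giving 16000 nM in this assay

Of the compounds shown here, two have been measured, and compound 2 has the lowest of the two numbers. Its nearest neighbour is compound 1, which stands slightly higher, but that gap lies within the scatter of repeated measurements, so the two cannot be placed in order of strength. Going by the values given here, compound 1 and compound 2 also differ in more than one place, so no single structural step links them.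

The unmeasured compound 3, `Cc1ccc(NC(=O)NC(=O)c2ccc(OCc3cccc(C(F)(F)F)c3)cc2)cc1-c1nc2ccccc2[nH]1`, differs from compound 2 in only one place: trifluoromethyl in place of chloro on an aromatic carbon. The rest of the molecule, including the shared core and the benzyl ether, is unchanged.

Among the compounds with values here, no measured step of this kind is available here. Exchanging chloro for trifluoromethyl on an aromatic carbon is a small change, and in the absence of any guiding step the expectation is a shift in this assay that does not go beyond the scatter, in either direction. The estimated step from compound 2 to compound 3 is a 1.1-fold lower number from compound 2 to compound 3 (0.03 log units; within the scatter). Compound 3 is thus expected to give about 15000 nM, with a range from 6000 nM to 40000 nM.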

Compound 3, half-maximal inhibitory concentration: 9640 nM
Compound 3: middle estimate off by 1.6-fold (0.19 log units), on the high side; measured number inside the range.
By their numbers in this assay, from the lowest: compounds 3, 2 and 1 (each within the scatter of the next, the first and the last beyond it).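

Going by these compounds alone, this is the only step here between compounds that differ in one place: in this assay, trifluoromethyl in place of chloro on the benzyl ether gives a 1.7-fold lower number from compound 2 to compound 3 (0.22 log units; within the scatter). This position therefore takes a group of 4 heavy atoms in place of a single chlorine with no difference that can be told apart from the ordinary variation between repeated measurements, so compound 2 and compound 3 cannot be placed in order of strength. No measurement shown here speaks to what lies behind this result.

From the compounds shown here alone, it remains open whether a different kind of group on this aromatic carbon, such as an amine, a carboxylic acid or a longer chain, would move the number beyond the scatter, or whether removing the substituent altogether would do so. Going by these compounds, it is also open whether the same exchange of chloro for trifluoromethyl would give a similar step on the benzyl ether of compound 1, which differs from compound 2 in more than one place.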